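The compounds below may be only part of what the source reports. "The series", "measured", "known", "first", "only" and "open" are said of these compounds alone.

Compound 1 `O=C(O)c1ccc(CN2CCC[C@H](O[C@H](CO)c3cc(Cl)cc(Cl)c3)[C@@H]2c2ccccc2)cc1` in an assay on isolated protein for activation of cGMP-dependent protein kinase 1 (Homo sapiens), read by ADP-Glo, with stated times of 30 min and 2 h (a higher number here means that more compound is needed for the effect, a lower number that less compound is needed), gives 77000 nM, the highest of the two numbers in hand. Compound 2 `COC(=O)Nc1cc(C(=O)O)ccc1CN1CCC[C@H](O[C@H](CO)c2cc(Cl)cc(Cl)c2)[C@@H]1c1ccccc1` gives 69000 nM, with a 1.1-fold lower number from compound 1 to compound 2 (0.05 log units; within the scatter). Compound 3 `CC(=O)NS(=O)(=O)c1ccc(CN2CCC[C@H](O[C@H](CO)c3cc(Cl)cc(Cl)c3)[C@@H]2c2ccccc2)cc1` reaches only a limit of the assay, > 200000 nM. Among the compounds with values here, the step of an at least 2.5-fold higher number from compound 1 to compound 3 (0.41 log units; beyond the scatter) is the one that bears on compound 4: both alter the carboxy group, whereas compound 2 adds a group elsewhere and hardly moves the number. Compound 4 `COC(=O)c1ccc(CN2CCC[C@H](O[C@H](CO)c3cc(Cl)cc(Cl)c3)[C@@H]2c2ccccc2)c(C)c1` carries a group of 11 heavy atoms (9 carbon, 2 oxygen; one six-membered aromatic ring of carbon only) in place of a group of 9 heavy atoms (7 carbon, 2 oxygen; one six-membered aromatic ring of carbon only), on a saturated chain carbon bound to an amine nitrogen in a ring. Replacing carboxy by acetylsulfamoyl gave a higher, limited number, and compound 4 likewise loses the carboxy while gaining a methyl. A modest step toward a higher number is therefore expected, a 2.1-fold higher number from compound 1 to compound 4 (0.32 log units; beyond the scatter), possibly reaching (the limit of > 200000 nM in this assay, at which 1 of the 3 values shown sits). Compound 4 is estimated at 160000 nM, within 60000 nM to 400000 nM.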

Compound 4, half-maximal effective concentration: > 200000 nM
Compound 4: no number, only a limit; the forecaster's own chance of this, stated with the estimate: 40%; middle value at least 1.2-fold (0.09 log units) from the limit.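

With an at least 2.5-fold higher number from compound 1 to compound 4 (0.41 log units; beyond the scatter), a second replacement of the 4-carboxyphenyl group, on the saturated chain carbon bound to an amine nitrogen in a ring, also gives a change beyond the scatter. Compound 4 gives only a limit of the assay, > 200000 nM. Both changes that remove the free carboxy group from compound 1 now end at that limit: the limit of > 200000 nM in this assay, at which 2 of the 4 values shown sit.

The methyl ester and the added ring methyl enter together, and their separate shares remain unresolved. Also open, as far as these compounds go, is whether a carboxylic acid carrying that methyl, or a primary amide in place of the carboxy group, gives a number in this assay.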